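Chloro to Methoxy on the Pendant Phenyl Ring

The compounds below may be only part of what the source reports. "The series", "measured", "known", "first", "only" and "open" are said of these compounds alone.

Among three compounds measured in a functional assay on cells for antagonist activity at prostaglandin E2 receptor EP1 subtype (Rattus norvegicus), read by fluorescence and calcium flux, with a stated time of 60 s (a lower number here means a stronger inhibitor, a higher number a weaker inhibitor), compound 3 `O=C(O)c1cccc(Cc2c(-c3ccc(Cl)cc3)nn3cc(Cl)ccc23)n1` gives 1100 nM, the second highest number of the three. Going by the values given here, compound 2 `O=C(O)c1cccc(Cc2c(-c3cccc(Cl)c3)nn3cc(Cl)ccc23)n1` gives 480 nM, and the step of a 2.3-fold higher number from compound 2 to compound 3 (0.36 log units; beyond the scatter) is the only change between measured compounds that touches the pendant phenyl ring. Compound 1 `O=C(O)c1cccc(Cc2c(-c3ccccc3)nn3ccccc23)n1`, which carries no chlorine at all, gives 2300 nM. The unmeasured compound 4 `COc1ccc(-c2nn3cc(Cl)ccc3c2Cc2cccc(C(=O)O)n2)cc1` differs from compound 3 by a single change: methoxy in place of chloro on an aromatic carbon. Among the compounds with values here, no measured pair bears directly on exchanging chloro for methoxy; the one step on this ring concerned only where the chloro sits and was modest in size. Within the data shown here, compound 1 and compound 3 differ in more than one place, so no single step is counted between them. On that thin basis a small move is expected, near the scatter, with a slight lean toward a higher number. Compound 4 is therefore estimated at 1500 nM, within 500 nM to 4500 nM. The expected step of a 1.4-fold higher number from compound 3 to compound 4 (0.13 log units; within the scatter) is small.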

Compound 4, half-maximal inhibitory concentration: 5400 nM
The estimate for compound 4 lay 3.6-fold (0.56 log units) below the measured number, outside the stated range (above it).
By their numbers in this assay, from the lowest: compound 2; then compound 3; then compound 1; then compound 4.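

In this assay, going by these compounds alone, the step from chloro to methoxy on the pendant phenyl ring is a 4.9-fold higher number from compound 3 to compound 4 (0.69 log units; beyond the scatter), which shows that the identity of the group at this place matters, whereas the earlier compounds showed only the effect of moving the chloro. Measured against the 3-chlorophenyl analogue, the change to 4-methoxyphenyl is an 11-fold higher number from compound 2 to compound 4 (1.05 log units; beyond the scatter), the only step rated large among those shown. No supporting measurement bears on this result.

The compounds shown leave open whether a 3-methoxyphenyl group would keep the lower number seen with the 3-chlorophenyl group in compound 2 480 nM, which would separate the effect of the group from that of its place. They also leave open how a methyl, a fluorine or an amine would compare with chloro and methoxy on this ring.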